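The source may hold more compounds than are shown below. What is called first, only, known or untested is meant among the compounds shown, and "the series" means these compounds.

Values in a functional assay on HeLa cells (Homo sapiens) for antiproliferative activity, read by CCK-8 assay, with a stated time of 48 h; on this read-out higher numbers stand for weaker inhibition and lower numbers for stronger inhibition:
Compound 1 `COc1ccc(/C=C\c2cc(OC)c(OC)c(OC)c2)cc1OCc1ccc(CN2CCCC[C@@H]2C(=O)O)cc1`: > 10000 nM, which is a limit.
Compound 2 `COc1ccc(/C=C\c2cc(OC)c(OC)c(OC)c2)cc1OCc1ccc(CN2CCCCC2C(=O)O)cc1`: 14200 nM
Compound 3 `COc1ccc(/C=C\c2cc(OC)c(OC)c(OC)c2)cc1OCc1ccc(CN2CC(C(=O)O)C2)cc1`: 6500 nM

Compound 3, at 6500 nM, has the lower of the two values that are actual numbers. Compound 4 `COc1ccc(/C=C\c2cc(OC)c(OC)c(OC)c2)cc1OCc1ccc(CNCCNC(C)=O)cc1` replaces its amine group: (2-acetamidoethyl)amino in place of 3-carboxyazetidin-1-yl on a saturated chain carbon bound to an aromatic carbon. Two measured steps change the group at this place: a 2.2-fold lower number from compound 2 to compound 3 (0.34 log units; beyond the scatter), and an at least 1.5-fold lower number from compound 1 to compound 3 (0.18 log units; that floor lies within the scatter). Both end in a ring bearing a carboxy group, so neither measures the loss of the ring or the carboxy group. For the measured compounds named here, no compound measured so far lacks them. A lower number in this assay is tentatively expected, with wide uncertainty, and the expected step is a 4.3-fold lower number from compound 3 to compound 4 (0.64 log units; beyond the scatter). The estimated value for compound 4 is 1500 nM, with an expected range of 150 nM to 9000 nM.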

Compound 4, half-maximal inhibitory concentration: 6400 nM
Compound 4: the middle estimate sits 4.3-fold (0.63 log units) below what was measured, and the stated range covers the measured number.
By their numbers in this assay, from the lowest: compounds 4 and 3 (each within the scatter of the next); then compound 2.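

Without a ring or a carboxy group on the saturated chain carbon bound to an aromatic carbon, the value in this assay stays level with that of 3-carboxyazetidin-1-yl, so neither feature is needed to keep it: a 1.0-fold lower number from compound 3 to compound 4 (0.01 log units; within the scatter). Against 2-carboxypiperidin-1-yl, (2-acetamidoethyl)amino gives a 2.2-fold lower number from compound 2 to compound 4 (0.35 log units; beyond the scatter). The remaining comparison reads only as a floor, an at least 1.5-fold lower number from compound 1 to compound 4 (0.19 log units; that floor lies within the scatter): the limit of > 10000 nM in this assay, at which 1 of the 4 values shown sits.

From the compounds shown here alone, whether an open-chain carboxylic acid, a primary amine or a longer chain carrying the acetamide would shift the value at this place remains open. The compounds shown also do not separate the contribution of the acetamide from that of the secondary amine.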